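Amide variation on the shared core: arylamide versus pyrrolidine

The source may hold more compounds than are shown below. What is called first, only, known or untested is meant among the compounds shown, and "the series" means these compounds.

Among the compounds with values here, compound 2 `C=CC(=O)Nc1ccc(-c2nc(Cl)cc(Nc3ccc(C(=O)N4CCCC4)cc3)n2)cc1` stands highest of the two numbers so far: in a functional assay on HL-60 cells (Homo sapiens) for antiproliferative activity, read by MTT assay, with a stated time of 48 h (a lower number here means a stronger inhibitor, a higher number a weaker inhibitor), compound 2 gives 15800 nM, whereas compound 1 `C=CC(=O)Nc1ccc(-c2nc(Cl)cc(Nc3ccc(C(=O)Nc4cc(C(F)(F)F)cc(C(F)(F)F)c4)cc3)n2)cc1` gives 4790 nM in this assay, a gap beyond the scatter. Compound 3 `C=CC(=O)Nc1ccc(-c2nc(Cl)cc(Nc3ccc(C(=O)Nc4cc(C)ccc4C)cc3)n2)cc1` differs from compound 2 by (2,5-dimethylphenyl)amino in place of pyrrolidin-1-yl on a carbonyl carbon. Within the data shown here, no measured pair shows this step directly. Compound 1, which also carries an amine on that carbonyl, gives 4790 nM in this assay. On that basis a moderate drop in the number is expected, a 2.6-fold lower number from compound 2 to compound 3 (0.42 log units; beyond the scatter), beyond the scatter. For compound 3 the estimate in this assay is 6000 nM, within 2500 nM to 15000 nM.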

Compound 3, half-maximal inhibitory concentration: 14900 nM
Compound 3: the middle estimate sits 2.5-fold (0.40 log units) below what was measured; the measured number falls inside the stated range.
By their numbers in this assay, from the lowest: compound 1; then compounds 3 and 2 (each within the scatter of the next).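

In this assay the exchange of pyrrolidin-1-yl for (2,5-dimethylphenyl)amino on this carbonyl carbon reads as a 1.1-fold lower number from compound 2 to compound 3 (0.03 log units; within the scatter) and so leaves the two compounds indistinguishable. An aryl group on the amide nitrogen is therefore not enough on its own to give the printed number of compound 1 at 4790 nM in this series. Nothing available explains this result.

Whether the trifluoromethyl groups of compound 1 account for its number remains open. So does the outcome for a morpholine, a piperazine or a simple chloro substituent on the aryl ring.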